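The compounds below may be only part of what the source reports. "The series", "measured", "known", "first", "only" and "open" are said of these compounds alone.

Of the compounds shown here, three built on one shared core have been tested in a functional assay on MKN-45 cells (Homo sapiens) for cytotoxicity, read by MTT assay, with a stated time of 72 h; on this read-out higher numbers stand for weaker inhibition and lower numbers for stronger inhibition. Compound 1 `COc1cc2c(Oc3ccc(NC(=O)c4nnn(-c5ccccc5)c4C)cc3F)ccnc2cc1OCCCN1CCCC1` gives 40 nM. Compound 2 `COc1cc2c(Oc3ccc(NC(=O)c4nnn(-c5ccccc5C(F)(F)F)c4C)cc3F)ccnc2cc1OCCCN1CCCC1` gives 70 nM, and compound 3 `COc1cc2c(Oc3ccc(NC(=O)c4nnn(-c5ccccc5C(F)(F)F)c4C(F)(F)F)cc3F)ccnc2cc1OCCCN1CCCC1` gives 60 nM. Compound 1 has the lowest of the three numbers, but its gaps to compounds 2 and 3 are within the scatter, so the three cannot be separated on these readings. Both measured steps replace a substituent on an aromatic carbon: a 1.8-fold higher number from compound 1 to compound 2 (0.24 log units; within the scatter) and a 1.2-fold lower number from compound 2 to compound 3 (0.07 log units; within the scatter), each within the scatter.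

Compound 4 `COc1cc2c(Oc3ccc(NC(=O)c4nnn(-c5ccccc5)c4C)cc3F)ccnc2cc1OCCCN1CCCCC1` differs from compound 1 in a single place: piperidin-1-yl in place of pyrrolidin-1-yl on a saturated chain carbon, three bonds along the chain from an oxygen on an aromatic ring. Among the measured compounds shown here, neither measured step touches this saturated chain or the ring at its end, so no measured step bears on the change, and the measured compounds give no guidance of their own on how this assay responds to it. With nothing measured on this part of the molecule, the plainest expectation is that the number stays close to that of compound 1. For compound 4 the expected step is a 1.1-fold higher number from compound 1 to compound 4 (0.05 log units; within the scatter), nothing beyond the scatter. Compound 4 is therefore estimated at 45 nM, with a range from 15 nM to 130 nM.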

Compound 4, half-maximal inhibitory concentration: 80 nM
Estimate against measurement, compound 4: 1.8-fold (0.25 log units) below, and the stated range covers the measured number.
By their numbers in this assay, from the lowest: compounds 1, 3, 2 and 4 (each within the scatter of the next).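

Among the compounds shown here, this is the first reading from the far end of the molecule, since the earlier steps changed only substituents on aromatic carbons. In this assay, exchanging pyrrolidin-1-yl for piperidin-1-yl gives a 2.0-fold higher number from compound 1 to compound 4 (0.30 log units; within the scatter). The two rings therefore cannot be told apart on these readings, and this position accepts the six-membered ring in place of the five-membered one with no step beyond the scatter. Nothing available explains how either ring acts on these cells.

The compounds shown carry only these two rings at this place, so it remains open how a morpholine ring, an open dimethylamino group or a 2-(pyrrolidin-1-yl)ethyl chain in place of the 3-(pyrrolidin-1-yl)propyl chain would read. Also open, from the compounds shown here alone, is whether the same ring swap would read alike on compound 2 and compound 3, which carry trifluoromethyl groups.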